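Adding a methyl to the piperidine tail of compound 1

This account rests on a few compounds, and the source may have more. Where it says the series, first, only, none or still open, it means among the compounds named here.

Measured so far:
compound 1 `COc1cc2c(Oc3ccc(NC(=O)c4nn(-c5ccccc5F)c(=O)c5ccccc45)cc3F)ccnc2cc1OCCCN1CCCCC1` gives 630 nM in a functional assay on HT-29 cells (Homo sapiens) for cytotoxicity, read by MTT assay, with a stated time of 72 h; on this read-out lower numbers stand for stronger inhibition and higher numbers for weaker inhibition
compound 2 `COc1cc2c(Oc3ccc(NC(=O)c4nn(-c5ccc(Br)cc5)c(=O)c5ccccc45)cc3F)ccnc2cc1OCCCN1CCCCC1` gives 770 nM in this assay

Within the data shown here, compound 1 shows the lowest of the two numbers, yet the only step to a measured neighbour, a 1.2-fold higher number from compound 1 to compound 2 (0.09 log units; within the scatter), lies within the scatter, so the two compounds cannot be told apart. Compound 3 `COc1cc2c(Oc3ccc(NC(=O)c4nn(-c5ccccc5F)c(=O)c5ccccc45)cc3F)ccnc2cc1OCCCN1CCC(C)CC1` is not yet measured. It keeps the 2-fluorophenyl of compound 1 and differs only at the far end of the molecule: methyl in place of hydrogen on a saturated ring carbon. Among the measured compounds shown here, no measured step touches this saturated ring, and the one step known, a 1.2-fold higher number from compound 1 to compound 2 (0.09 log units; within the scatter), was too small to show any sensitivity at all. A single methyl on this ring is therefore expected to leave this assay essentially unchanged, giving a 1.1-fold lower number from compound 1 to compound 3 (0.02 log units; within the scatter), no step beyond the scatter. Compound 3 is estimated at 600 nM, with a range from 250 nM to 1500 nM.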

Compound 3, half-maximal inhibitory concentration: 510 nM
Compound 3: the middle estimate sits 1.2-fold (0.07 log units) above what was measured; measured number inside the range.
By their numbers in this assay, from the lowest: compounds 3, 1 and 2 (each within the scatter of the next).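

Among these compounds, replacing piperidin-1-yl with 4-methylpiperidin-1-yl gives the first measured change on the saturated ring, and in this assay it amounts to a 1.2-fold lower number from compound 1 to compound 3 (0.09 log units; within the scatter). This ring carbon, three ring bonds from the ring nitrogen, therefore accepts one added methyl with no readable shift in the number, whereas the earlier step spoke only to the group on the aromatic nitrogen. Nothing given here offers an explanation for this result.

As far as these compounds go, it remains open whether a larger group at this ring carbon, such as phenyl or a hydroxyl group, or morpholine in place of the whole piperidine ring, would move the number beyond the scatter. From the compounds shown here alone, it is also open whether the same methyl would behave alike when paired with the 4-bromophenyl group of compound 2.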